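Bombesin receptor subtype-3 agonists: imidazole substituent series

The compounds below may be only part of what the source reports. "The series", "measured", "known", "first", "only" and "open" are said of these compounds alone.

Measured compounds:
- compound 1, `O=C(O)c1ccccc1-c1ccc(CCc2ncc(CC3CCCC3)[nH]2)cc1`: 7.9 nM
- compound 2, `O=C(O)c1ccccc1-c1ccc(CCc2ncc(-c3ccccc3)[nH]2)cc1`: 872 nM

Both were tested in an in vitro functional assay on cells for agonist activity at Bombesin receptor subtype-3 (Mus musculus), read by luminescence and calcium flux; a lower number here means that less compound is needed, a higher number that more compound is needed for the effect. Among the measured compounds shown here, compound 2 gives the higher of the two numbers; the only measured step, a 110-fold higher number from compound 1 to compound 2 (2.04 log units; beyond the scatter), separates it from compound 1.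

Compound 3, `CCC(C)(CC)Cc1cnc(CCc2ccc(-c3ccccc3C(=O)O)cc2)[nH]1`, is not yet measured. Its change from compound 2 is 2-ethyl-2-methylbutyl in place of phenyl on an aromatic carbon. For the measured compounds named here, the one measured step that bears on this change is a 110-fold higher number from compound 1 to compound 2 (2.04 log units; beyond the scatter), which shows that replacing a cyclopentylmethyl by a phenyl at this carbon raises the number sharply. Compound 3 reverses that move: the phenyl, one six-membered aromatic ring of carbon only, leaves, and an open chain with no ring, 2-ethyl-2-methylbutyl, enters. The entering group is closer in kind to the cyclopentylmethyl of compound 1 than to the phenyl of compound 2, so a large step downward is expected in this assay, on the order of the reverse of the measured step, though the chain is not the same as the ring of compound 1 and the match may be only partial.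

For compound 3 the expected step is a 58-fold lower number from compound 2 to compound 3 (1.76 log units; beyond the scatter). Compound 3 is estimated at 15 nM in this assay, with a range from 4 nM to 70 nM.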

Compound 3, half-maximal effective concentration: 30 nM
For compound 3 the middle estimate is 2.0-fold (0.30 log units) below the measured one, within the range that was stated.
By their numbers in this assay, from the lowest: compound 1; then compound 3; then compound 2.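

In this assay the open chain 2-ethyl-2-methylbutyl regains most of what was lost with phenyl on this aromatic carbon (a 29-fold lower number from compound 2 to compound 3 (1.46 log units; beyond the scatter)), so a ring in the substituent is not required for a low number at this position. The chain is still not equal to the cyclopentyl-bearing group of compound 1 (a 3.8-fold higher number from compound 1 to compound 3 (0.58 log units; beyond the scatter)), a modest step that is much smaller than the step separating compound 3 from the phenyl compound, so the saturated ring and the branched chain differ here, but only modestly. No accompanying measurement explains either step.

Going by these compounds, it remains open whether the high number of compound 2 goes with the aromatic ring itself or with a ring attached directly to the carbon, a question that a benzyl group and a directly attached cyclohexyl would separate. Also open, on these data alone, is how far this position accepts anything other than plain carbon groups, such as a chain ending in an amine or a hydroxyl, and whether a shorter chain such as neopentyl keeps the low number.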